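Notes on acetyl groups on the ring nitrogen

The source may hold more compounds than are shown below. What is called first, only, known or untested is meant among the compounds shown, and "the series" means these compounds.

Compound 1 `COc1ccc(-c2c(-c3cc(OC)c(OC)c(OC)c3)noc2N)cc1OC`: in a functional assay on A549 cells (Homo sapiens) for cytotoxicity, read by MTT assay, with a stated time of 48 h (a higher number here means a weaker inhibitor, a lower number a stronger inhibitor), compound 1 gives > 50000 nM, which is a limit of the assay and not a number.
Compound 2 `COc1ccc(-c2c(-c3cc(OC)c(OC)c(OC)c3)noc2NC(C)=O)cc1`: in this assay compound 2 gives 10700 nM.
Compound 3 `COc1ccc(-c2c(-c3cc(OC)c(OC)c(OC)c3)noc2NC(C)=O)cc1OC`: in this assay compound 3 gives 19800 nM.

The change from compound 1 to compound 3 is acetyl in place of hydrogen on a nitrogen on an aromatic ring. It produced an at least 2.5-fold lower number from compound 1 to compound 3 (0.40 log units; beyond the scatter); the step can only be bounded because compound 1 sits at the limit of > 50000 nM in this assay, at which 1 of the 3 values shown sits. Compound 2 and compound 3 differ by methoxy in place of hydrogen on an aromatic carbon, with a 1.9-fold higher number from compound 2 to compound 3 (0.27 log units; within the scatter), so the two values are read as equal. How the cores of compound 1 and compound 2 differ is not broken down here.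

Compound 4 `COc1ccc(-c2c(-c3cc(OC)c(OC)c(OC)c3)noc2N(C(C)=O)C(C)=O)cc1` is not yet measured. Its difference from compound 2 is acetyl in place of hydrogen on an amide-type nitrogen. This is the same kind of change as from compound 1 to compound 3, not the same: there the nitrogen is on an aromatic ring whose other neighbour is aromatic carbon, here it is an amide-type nitrogen whose other neighbours are aromatic carbon and carbonyl carbon. For the measured compounds named here, the expected step is a 1.3-fold lower number from compound 2 to compound 4 (0.13 log units; within the scatter), resting on compound 2 at 10700 nM and on the earlier acetyl step an at least 2.5-fold lower number from compound 1 to compound 3 (0.40 log units; beyond the scatter), though the acetamido-to-diacetylamino change has no measured precedent. Compound 4 is estimated at 8000 nM, expected between 2500 nM and 30000 nM.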

Compound 4, half-maximal inhibitory concentration: 430 nM
Compound 4: the middle estimate sits 19-fold (1.27 log units) above what was measured; the measured number lies below the stated range.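

In this assay, acetyl in place of hydrogen on the amide-type nitrogen gives a 25-fold lower number from compound 2 to compound 4 (1.40 log units; beyond the scatter), a large step. The same change lowers the number on both cores, so its direction carries over in these two pairs, though the nitrogen carrying it is of a different kind in each pair, and the two sizes cannot be ranked: the same change on two cores in this assay, an at least 2.5-fold lower number (0.40 log units; beyond the scatter) from compound 1 to compound 3 and a 25-fold lower number (1.40 log units; beyond the scatter) from compound 2 to compound 4; the limit leaves it open whether they differ. Compound 1 stands at a limit of the assay and not at a number, so the earlier step is only a bound and says nothing firm about how much of the effect transfers: the limit of > 50000 nM in this assay, at which 1 of the 4 values shown sits.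

The compounds shown leave open whether diacetylamino on the core of compound 3 would give a number in this assay close to that of compound 4. They also leave open whether the step needs acetyl itself, or whether propionyl, benzoyl or a methyl on the same nitrogen would serve in its place.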